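From 4-aminophenyl to 3-hydroxyphenyl on a carbonyl carbon

The source may report more compounds than this note shows. Statements on the series, on what has been measured and on what is new or still open speak of the compounds shown alone.

Values so far in a physicochemical assay for lipophilicity, read by HPLC, measured as octanol-water partition (a lower number here means a more polar compound, a higher number a more lipophilic compound), are as follows
Compound 1 `O=C(N/N=C/c1ccc2no[n+]([O-])c2c1)c1ccccc1O` gives 1.3
Compound 2 `Nc1ccc(C(=O)N/N=C/c2ccc3no[n+]([O-])c3c2)cc1` gives 1.2

Among the measured compounds shown here, compound 2 lies within the scatter of compound 1, the only other compound measured, so the two cannot be told apart. Compound 3 `O=C(N/N=C/c1ccc2no[n+]([O-])c2c1)c1cccc(O)c1` has not yet been measured in this assay and carries 3-hydroxyphenyl in place of 4-aminophenyl on a carbonyl carbon. For the measured compounds named here, one measured step bears on this change, an exchange between 2-hydroxyphenyl in compound 1 and 4-aminophenyl on the same carbonyl carbon, and it was small (a number 0.10 log units lower from compound 1 to compound 2 (within the scatter)). Going by the values given here, with only that step to go on, no change beyond the scatter is expected (a number 0.10 log units higher from compound 2 to compound 3 (within the scatter)). The value of compound 3 is estimated at 1.3 (expected range 0.9 to 1.7).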

Compound 3, partition coefficient: 1.2
Compound 3: middle estimate off by 0.10 log units, on the high side, within the range that was stated.
By their numbers in this assay, from the lowest: compounds 2, 3 and 1 (each within the scatter of the next).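

In this assay, 3-hydroxyphenyl on this carbonyl carbon cannot be told apart from 4-aminophenyl (no change at the digits printed from compound 2 to compound 3 (within the scatter)). It also cannot be told apart from 2-hydroxyphenyl (a number 0.10 log units lower from compound 1 to compound 3 (within the scatter)). Where the earlier compounds offered a single exchange at this place, three groups now give values that all lie within the scatter of one another, so neither the exchange of 4-aminophenyl for 3-hydroxyphenyl nor that of 2-hydroxyphenyl for 3-hydroxyphenyl gives a readable difference. No measurement at hand offers an explanation for these results.

On these data alone, what remains open is whether any group at this carbonyl carbon gives a step beyond the scatter, since all three compounds carry a phenyl ring with a single hydroxyl or amino substituent. A carboxylic acid on that ring, or a longer alkyl chain in its place, could test this.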